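Amide Aryl Exchange on a Shared Core

The compounds below may be only part of what the source reports. "The series", "measured", "known", "first", "only" and "open" are said of these compounds alone.

Of the compounds shown here, two built on one shared core have been tested in a functional assay on HeLa cells (Homo sapiens) for antiproliferative activity, read by CCK-8 assay, with a stated time of 72 h; on this read-out lower numbers stand for stronger inhibition and higher numbers for weaker inhibition. Compound 1 `COc1ccccc1C(=O)Nc1cccc(-c2oc3cc(-c4ccc(F)cc4)ccc3c(=O)c2O)c1` gives 14100 nM. Going by the values given here, compound 2 `O=C(Nc1cccc(-c2oc3cc(-c4ccc(F)cc4)ccc3c(=O)c2O)c1)c1cc(F)cc(F)c1` gives 3380 nM, the lowest of the two numbers, and the single measured step, a 4.2-fold lower number from compound 1 to compound 2 (0.62 log units; beyond the scatter), lies beyond the scatter. Compound 3 `O=C(Nc1cccc(-c2oc3cc(-c4ccc(F)cc4)ccc3c(=O)c2O)c1)c1ccc([N+](=O)[O-])cc1` has not been measured. It differs from compound 2 in one place: 4-nitrophenyl in place of 3,5-difluorophenyl on a carbonyl carbon. Among the compounds with values here, the one measured step bears on this only loosely: it concerns the same carbonyl carbon but exchanges a different pair of groups, 2-methoxyphenyl for 3,5-difluorophenyl. Nothing measured shows what 4-nitrophenyl does on that carbonyl carbon. For compound 3 the expected step is a 1.2-fold higher number from compound 2 to compound 3 (0.07 log units; within the scatter), nothing beyond the scatter in either direction. In this assay compound 3 is estimated at 4000 nM, within a range from 1300 nM to 12000 nM.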

Compound 3, half-maximal inhibitory concentration: 12300 nM
Beside the measured number, compound 3's estimate is 3.1-fold (0.49 log units) below it; measured number above the stated range.
By their numbers in this assay, from the lowest: compound 2; then compounds 3 and 1 (each within the scatter of the next).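

With a second exchange at this carbonyl carbon, a 3.6-fold higher number from compound 2 to compound 3 (0.56 log units; beyond the scatter) in this assay, 3,5-difluorophenyl now has a number clearly apart from those of both other aryl groups, as compound 2 stands lowest of the three. The remaining pair adds something new, because a 1.1-fold lower number from compound 1 to compound 3 (0.06 log units; within the scatter) shows that 4-nitrophenyl and 2-methoxyphenyl, though different in their groups and in the substituted ring positions their names give, cannot be told apart here.

The compounds shown leave open how an unsubstituted phenyl, a 4-fluorophenyl or a 4-aminophenyl would read on the same carbonyl carbon. They also leave open whether a pyridine ring or a small alkyl chain could take the place of the aryl group altogether.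

No measurement offered here accounts for these differences.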